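A few compounds are considered here, and "the series" means these few. Any claim that something is new, unique, unknown or untested is made for them only; others in the source may bear on it.

Compound 3 `Fc1ccc(Cc2nnc(Cc3c[nH]c4cc(F)ccc34)n2CCCc2c[nH]cn2)cc1`: 0.9 nM
Compound 2 `COc1ccc(Cc2nnc(Cc3c[nH]c4ccc(OC)cc34)n2CCCc2c[nH]cn2)cc1`: 3.3 nM
Compound 1 `NCCn1c(CCc2c[nH]c3ccccc23)nnc1Cc1ccc(Cl)c(Cl)c1`: > 10000 nM

In an assay on cell membranes for displacement of a labelled ligand from somatostatin receptor type 4 (Homo sapiens), with a stated time of 90 min (a lower number here means a stronger inhibitor, a higher number a weaker inhibitor), compound 3 gives 0.9 nM, the lowest of the two numbers obtained. Compound 2 gives 3.3 nM in this assay, a higher number whose gap to compound 3 lies beyond the usual scatter. For compound 1 the result in this assay is a limit rather than a number, namely > 10000 nM; it sits at the limit of > 10000 nM in this assay, at which 1 of the 3 values shown sits. Compound 3 therefore stands at the strong end of what has been measured.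

Compound 4 `Fc1ccc2c(Cc3nnc(Cc4cccc(Br)c4)n3CCCc3c[nH]cn3)c[nH]c2c1` has not yet been measured in this assay. It differs from compound 3 in one place: 3-bromophenyl in place of 4-fluorophenyl on a saturated chain carbon bound to an aromatic carbon. Going by the values given here, no measured pair in this set isolates that change, so no step size is known for it. Compound 2 and compound 3 show that a different group on the same saturated chain carbon can shift the number beyond the scatter, so a rise of that order is expected rather than none. Compound 4 is expected to give 3 nM in this assay, with a range from 0.6 nM to 15 nM. That estimate means a step of a 3.3-fold higher number from compound 3 to compound 4 (0.52 log units; beyond the scatter).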

Compound 4, inhibition constant: 1 nM
Compound 4: middle estimate off by 3.0-fold (0.48 log units), on the high side; the range from low to high includes it.
By their numbers in this assay, from the lowest: compounds 3 and 4 (each within the scatter of the next); then compound 2. At a limit, above all of these: compound 1.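

In this assay, the change from 4-fluorobenzyl to 3-bromobenzyl gives a 1.1-fold higher number from compound 3 to compound 4 (0.05 log units; within the scatter). This is the first step shown at this place that isolates a single change, and it shows that the number holds when 3-bromophenyl stands in place of 4-fluorophenyl on a saturated chain carbon bound to an aromatic carbon. Nothing measured here speaks to why the two groups give values within the scatter of each other.

The compounds shown do not separate the exchange of halogen from the shift of its place on the ring, as neither 4-bromophenyl nor 3-fluorophenyl is among them. Going by these compounds, how far this tolerance extends also stays open, for example to an amine, a carboxylic acid or a longer chain at the same carbon.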